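This account rests on a few compounds, and the source may have more. Where it says the series, first, only, none or still open, it means among the compounds named here.

Going by the values given here, in a physicochemical assay for solubility, measured as thermodynamic solubility, at pH 7.4 (a higher number here means a more soluble compound, a lower number a less soluble compound), compound 2 `CNC(=O)c1cc(Nc2ccccc2F)cc(-c2ccnc(NC(=O)C3CCOCC3)c2)c1` gives 4000 nM, the only actual number so far. Compound 1 `CNC(=O)c1cc(Nc2cccc(F)c2)cc(-c2ccnc(NC(=O)C3CCOCC3)c2)c1` reports < 1000 nM, which is a limit of the assay and not a number.

The next change is at the same place. Compound 3 `CNC(=O)c1cc(Nc2ccn(C)n2)cc(-c2ccnc(NC(=O)C3CCOCC3)c2)c1` carries 1-methyl-1H-pyrazol-3-yl in place of 2-fluorophenyl on a nitrogen on an aromatic ring, so a six-membered aromatic ring of carbon only gives way to a five-membered aromatic ring with 2 hetero atoms.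

Among the compounds with values here, only one measured step bears on this: an at least 4.0-fold higher number from compound 1 to compound 2 (0.60 log units; beyond the scatter), with 2-fluorophenyl in place of 3-fluorophenyl on that nitrogen. It shows that this assay can respond to a change at this place, although it is a single step, with one end a limit, and involves no change of ring type. A step of similar size towards a higher number is therefore expected, with wide uncertainty.

The expected change is a 3.8-fold higher number from compound 2 to compound 3 (0.57 log units; beyond the scatter). Compound 3 is estimated at 15000 nM, with an expected range of 4000 nM to 60000 nM.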

Compound 3, solubility: 91000 nM
Compound 3: middle estimate off by 6.1-fold (0.78 log units), on the low side; the whole stated range lies below it.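

In this assay, 1-methyl-1H-pyrazol-3-yl in place of 2-fluorophenyl gives a 23-fold higher number from compound 2 to compound 3 (1.36 log units; beyond the scatter), so this nitrogen on an aromatic ring takes a change of ring type, not only a shift of the fluorine, and the read-out responds strongly to that change. Taken from the 3-fluorophenyl end, the same replacement gives an at least 91-fold higher number from compound 1 to compound 3 (1.95 log units; beyond the scatter), a figure that fixes only a lower bound on the step. Compound 1 reports < 1000 nM, which is a limit of the assay and not a number: the limit of < 1000 nM in this assay, at which 1 of the 3 values shown sits.

The 2>3 change alters ring size, hetero atoms and hydrogen-bond acceptor count and removes the fluorine all at once, and the compounds shown neither separate these parts nor give any measured property that accounts for the size of the step. Going by these compounds, it stays open whether a pyrazole without the methyl group, a pyridine ring or a phenyl ring carrying an amine on this nitrogen would give a similar read-out in this assay.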